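Replacing nitro with cyano in a cytotoxicity series

A few compounds are considered here, and "the series" means these few. Any claim that something is new, unique, unknown or untested is made for them only; others in the source may bear on it.

Of the compounds shown here, three sharing one core have been tested in an ADME assay on NIH3T3 cells (Mus musculus) for cytotoxicity, read by XTT assay, with a stated time of 24 h (a higher number here means a weaker inhibitor, a lower number a stronger inhibitor), and only one of them returned a number. Compound 1 (`Cc1ccc(-c2csc(N3N=C(c4ccc(C)s4)CC3c3ccc(F)cc3)n2)cc1`) reads > 500 ug/mL and this is a limit of the assay. Compound 3 (`Fc1ccc(C2CC(c3ccc(Cl)s3)=NN2c2nc(-c3ccc(Br)cc3)cs2)cc1`) reads > 500 ug/mL and this too is a limit. Compound 2 (`Cc1ccc(C2=NN(c3nc(-c4ccc([N+](=O)[O-])cc4)cs3)C(c3ccc(F)cc3)C2)s1`) gives 15.6 ug/mL as the only number shown, so it has no measured number to stand against.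

The next compound is compound 4 (`Cc1ccc(C2=NN(c3nc(-c4ccc(C#N)cc4)cs3)C(c3ccc(F)cc3)C2)s1`), in which the 4-nitrophenyl of compound 2 becomes 4-cyanophenyl. The counted difference is cyano in place of nitro on an aromatic carbon and the change lies on an aromatic carbon of a six-membered aromatic ring of carbon only, para to a large group.

Within the data shown here, one measured step bears on this position. Nitro in place of methyl gave an at least 32-fold lower number from compound 1 to compound 2 (1.50 log units; beyond the scatter) in this assay and that step rests on the limit of > 500 ug/mL in this assay, at which 2 of the 3 values shown sit, as its starting point. Among the measured compounds shown here, no compound with a cyano group has been measured. Compound 4 gives up the nitro group of that step, so a partial return towards the limit seems likely. The expected change is an 8.0-fold higher number from compound 2 to compound 4 (0.90 log units; beyond the scatter) in this assay and it is a moderate rise with wide uncertainty. For compound 4 the estimate is 125 ug/mL with an expected range from 15 ug/mL to 500 ug/mL as its span.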

Compound 4, half-maximal inhibitory concentration: 250 ug/mL
Beside the measured number, compound 4's estimate is 2.0-fold (0.30 log units) below it; the measured number falls inside the stated range.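

The earlier compounds shown here showed only that nitro in place of methyl lowered the number in this assay; the new result shows that this low number does not carry over to another group at the same aromatic carbon, with cyano in place of nitro giving a 16-fold higher number from compound 2 to compound 4 (1.20 log units; beyond the scatter). Set against methyl, cyano gives an at least 2.0-fold lower number from compound 1 to compound 4 (0.30 log units; that floor lies within the scatter), a floor that lies within the scatter, so no difference between cyano and methyl can be claimed at this position, and among the compounds compared here the low number stays with the 4-nitrophenyl of compound 2. Compound 1 reads as a limit of the assay and not as a number, so this comparison has only a floor, and compound 3 is likewise a limit: the limit of > 500 ug/mL in this assay, at which 2 of the 4 values shown sit.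

On these data alone, how far the number of cyano compound 4 could be moved by an amine, a carboxylic acid or a methoxy group on this same aromatic carbon remains open. Also open, as far as these compounds go, is whether the step from cyano to nitro would be of similar size on a core carrying other groups elsewhere, since compound 3 differs from the other compounds in more than one place.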